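Methoxy added to compound 2: cytotoxicity notes

A few compounds are considered here, and "the series" means these few. Any claim that something is new, unique, unknown or untested is made for them only; others in the source may bear on it.

- compound 1 `COc1ccc(-c2ccc(OC)c3ccccc23)c2c1C=NCC2`: 34300 nM
- compound 2 `Oc1ccc(-c2ccc(O)c3ccccc23)c2c1C=NCC2`: 94200 nM
- compound 3 `COc1cccc2c(-c3ccc(O)c4c3CC(C)(C)N=C4)ccc(OC(C)C)c12`: > 100000 nM (a limit)

All three values come from an ADME assay on L6 cells (Rattus norvegicus) for cytotoxicity; a higher number here means a weaker inhibitor, a lower number a stronger inhibitor. Compound 3 gives > 100000 nM, which is a limit of the assay and not a number. Of the two actual numbers, compound 2 has the higher at 94200 nM. Its nearest neighbour, compound 1 at 34300 nM, lies lower by more than the scatter.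

The next compound is compound 4 `COc1cccc2c(-c3ccc(O)c4c3CCN=C4)ccc(O)c12`, which has methoxy in place of hydrogen on an aromatic carbon. Among the measured compounds shown here, no measured step isolates this change, so the expectation is loose. Compound 3 also carries a methoxy and reaches only a limit. Compound 1 shows that a number is possible at 34300 nM.

The expected 1.3-fold lower number from compound 2 to compound 4 (0.13 log units; within the scatter) is no change beyond the scatter in this assay. For compound 4 the estimate is 70000 nM, with an expected range from 35000 nM to 100000 nM.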

Compound 4, half-maximal inhibitory concentration: 98200 nM
Compound 4: middle estimate off by 1.4-fold (0.15 log units), on the low side; the range from low to high includes it.
By their numbers in this assay, from the lowest: compound 1; then compounds 2 and 4 (each within the scatter of the next). At a limit, above all of these: compound 3.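

In this assay, among the compounds shown here, methoxy in place of hydrogen on an aromatic carbon, ortho to a fused ring and meta to a fused ring, gives the first step that changes one place only: a 1.0-fold higher number from compound 2 to compound 4 (0.02 log units; within the scatter). At this position the added methoxy therefore shows no change beyond the scatter, which compound 1 and compound 3 could not show, as each differs from compound 2 in more than one place. Compound 3 stands at a limit and not at a number, and the readable range ends there: the limit of > 100000 nM in this assay, at which 1 of the 4 values shown sits.

As far as these compounds go, what an amine, a carboxylic acid or a longer alkoxy chain would do at this position remains open. Also open, from the compounds shown here alone, is whether methoxy here gives the same step in a compound whose value lies further from that limit.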